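The source may report more compounds than this note shows. Statements on the series, on what has been measured and on what is new or still open speak of the compounds shown alone.

Three compounds share one core and differ only in the amide attached to its carbonyl carbon. Compound 3 `CC1CCN(C(=O)[C@@H]2C[C@H](S(=O)(=O)c3ccccc3)C[C@H]2C(=O)NC2(C#N)CC2)CC1` gives 0.5 nM in an assay on isolated protein for inhibition of cathepsin S (Homo sapiens), read by fluorescence, with a stated time of 20 min; on this read-out lower numbers stand for stronger inhibition and higher numbers for weaker inhibition; this is the lowest of the three numbers, yet every gap to the others lies within the scatter. Compound 1 `N#CC1(NC(=O)[C@@H]2C[C@@H](S(=O)(=O)c3ccccc3)C[C@H]2C(=O)N2CC3CCC(C2)O3)CC1` gives 1 nM, and compound 2 `N#CC1(NC(=O)[C@@H]2C[C@@H](S(=O)(=O)c3ccccc3)C[C@H]2C(=O)N2CCCCC2)CC1` gives 0.8 nM. The steps of a 1.3-fold lower number from compound 1 to compound 2 (0.10 log units; within the scatter), a 2.0-fold lower number from compound 1 to compound 3 (0.30 log units; within the scatter) and a 1.6-fold lower number from compound 2 to compound 3 (0.20 log units; within the scatter) all stay within the scatter, so swapping the whole ring on the carbonyl carbon, or adding a methyl on a saturated ring carbon, has left the read-out essentially unchanged.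

Compound 4 `N#CC1(NC(=O)[C@@H]2C[C@@H](S(=O)(=O)c3ccccc3)C[C@H]2C(=O)N2CCC(O)CC2)CC1` is not yet measured. It differs from compound 3 by hydroxy in place of methyl on a saturated ring carbon. Within the data shown here, the one step at the same place, a 1.6-fold lower number from compound 2 to compound 3 (0.20 log units; within the scatter), was within the scatter, and the larger ring swaps also changed little, so no step beyond the scatter is expected, in either direction. The expected step is a 1.6-fold higher number from compound 3 to compound 4 (0.20 log units; within the scatter). Compound 4 is therefore estimated at 0.8 nM, with a range from 0.3 nM to 2.5 nM.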

Compound 4, half-maximal inhibitory concentration: 1 nM
Estimate against measurement, compound 4: 1.3-fold (0.10 log units) below; measured number inside the range.
By their numbers in this assay, from the lowest: compounds 3, 2, 1 and 4 (each within the scatter of the next).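

Among these compounds, at the saturated ring carbon three ring bonds from the ring nitrogen, the earlier compounds carried only hydrogen or methyl, whereas compound 4 carries hydroxy, which adds a hydrogen-bond donor and a hydrogen-bond acceptor. Even so, this assay shows a 2.0-fold higher number from compound 3 to compound 4 (0.30 log units; within the scatter) and a 1.3-fold higher number from compound 2 to compound 4 (0.10 log units; within the scatter), so hydrogen, methyl and hydroxy at this position all give numbers within the scatter of one another, and the comparison with the two-ring group on the carbonyl carbon shows no change at the digits printed from compound 1 to compound 4 (within the scatter). No measurement is available to explain why this change leaves the number within the scatter.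

On these data alone, what remains open is whether any group at this position can move the number beyond the scatter. A charged amine, a carboxylic acid or a longer chain such as n-butyl would test this, and the same swap could also behave differently on another core.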